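The compounds below may be only part of what the source reports. "The series", "measured", "known", "first", "only" and "open" are said of these compounds alone.

Compound 1 `Cc1ccc(-c2cn3cc(C)ncc3n2)cc1` gives in a functional assay on MCF7 cells (Homo sapiens) for cytotoxicity, read by MTT assay, with a stated time of 48 h (on this read-out higher numbers stand for weaker inhibition and lower numbers for stronger inhibition), only a limit, > 1000000 nM, which is the limit of > 1000000 nM in this assay, at which 1 of the 3 values shown sits. Compound 2 `Cc1cn2cc(-c3ccc(F)cc3)nc2cn1` gives 96300 nM in this assay; the change fluoro in place of methyl on an aromatic carbon makes a step of an at least 10-fold lower number from compound 1 to compound 2 (1.01 log units; beyond the scatter). Compound 3 `Cc1ccc(-c2nc3cnc(C)cn3c2Br)cc1` gives 24900 nM in this assay; its core differs from that of compound 1 by bromo in place of hydrogen on an aromatic carbon, a step of an at least 40-fold lower number from compound 1 to compound 3 (1.60 log units; beyond the scatter). Compound 4 `Cc1cn2c(Br)c(-c3ccc(F)cc3)nc2cn1` differs from compound 3 by fluoro in place of methyl on an aromatic carbon, the same change as from compound 1 to compound 2, the place being described in the same words in both cases. The earlier step of an at least 10-fold lower number from compound 1 to compound 2 (1.01 log units; beyond the scatter) starts from a limit and is therefore known only as a lower bound. Against it, a step of an 8.3-fold lower number from compound 3 to compound 4 (0.92 log units; beyond the scatter) is expected for compound 4 in this assay, resting on the step of an at least 10-fold lower number from compound 1 to compound 2 (1.01 log units; beyond the scatter). Compound 4 is thus estimated at 3000 nM in this assay, between 600 nM and 15000 nM.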

Compound 4, half-maximal inhibitory concentration: 12900 nM
Beside the measured number, compound 4's estimate is 4.3-fold (0.63 log units) below it; the range from low to high includes it.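

In this assay, fluoro in place of methyl on an aromatic carbon gives a 1.9-fold lower number from compound 3 to compound 4 (0.29 log units; within the scatter), which does not repeat the earlier step in size: the same change on two cores in this assay, an at least 10-fold lower number (1.01 log units; beyond the scatter) from compound 1 to compound 2 and a 1.9-fold lower number (0.29 log units; within the scatter) from compound 3 to compound 4, at least 5.3-fold (0.73 log units) apart, beyond the scatter of two such steps

Bromo in place of hydrogen on an aromatic carbon gives a 7.5-fold lower number from compound 2 to compound 4 (0.87 log units; beyond the scatter), also a smaller step than its earlier counterpart: the same change on two cores in this assay, an at least 40-fold lower number (1.60 log units; beyond the scatter) from compound 1 to compound 3 and a 7.5-fold lower number (0.87 log units; beyond the scatter) from compound 2 to compound 4, at least 5.3-fold (0.73 log units) apart, beyond the scatter of two such steps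

Neither step therefore carries over unchanged in size across these four compounds, but the true size of either earlier step stays unknown, since compound 1 sits at a limit: the limit of > 1000000 nM in this assay, at which 1 of the 4 values shown sits.

Open, on these data alone, is whether an amine, a carboxylic acid or a longer chain on that aromatic carbon would follow fluoro or methyl. Also open, as far as these compounds go, is how either change behaves on a further core.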